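The source may report more compounds than this note shows. Statements on the series, on what has been measured and on what is new or still open speak of the compounds shown alone.

Of the compounds shown here, three built on one shared core have been tested in a functional assay on KB cells (Homo sapiens) for cytotoxicity, read by MTT assay, with a stated time of 72 h; a higher number here means a weaker inhibitor, a lower number a stronger inhibitor. Compound 3 `COc1ccccc1/C(=C\c1cn(C(C)=O)c2ccc(OCc3ccccc3)cc12)C(=O)O` carries a 2-methoxyphenyl group, and in this assay compound 3 reaches only the limit of the assay, > 100000 nM, so its true value is not known. Compound 1 `COc1cccc(/C(=C\c2cn(C(C)=O)c3ccc(OCc4ccccc4)cc23)C(=O)O)c1` likewise reaches only a limit in this assay, > 100000 nM. Compound 2 `CC(=O)n1cc(/C=C(/C(=O)O)c2ccc(OCc3ccccc3)cc2)c2cc(OCc3ccccc3)ccc21` gives a readable number in this assay, 43000 nM. Compound 3 thus stands at the weak end of what is shown, at the limit described by the limit of > 100000 nM in this assay, at which 2 of the 3 values shown sit. The single measured step among these compounds, a step that the two limits leave unreadable from compound 1 to compound 3, cannot be read because the limit of > 100000 nM in this assay, at which 2 of the 3 values shown sit, covers both of its ends.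

Compound 4 `CC(=O)n1cc(/C=C(/C(=O)O)c2ccc(Cl)cc2)c2cc(OCc3ccccc3)ccc21` differs from compound 3 by 4-chlorophenyl in place of 2-methoxyphenyl on a double-bonded chain carbon bound to a carbonyl carbon and a double-bonded chain carbon. Among the compounds with values here, no measured step exchanges a methoxyphenyl for a chlorophenyl, so no size or direction for this change can be taken from the measured steps, and the only readable number among the three compounds is that of compound 2, 43000 nM. Compound 4 is therefore estimated to fall near 60000 nM, in a range from 20000 nM to 150000 nM. The step this estimate implies is an at least 1.6-fold lower number from compound 3 to compound 4 (0.22 log units; that floor lies within the scatter), with a real chance that the assay again reports only a limit.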

Compound 4, half-maximal inhibitory concentration: > 100000 nM
Compound 4: no number, only a limit; the forecaster's own chance of this, stated with the estimate: 40%; middle value at least 1.6-fold (0.22 log units) away from the limit.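

In this assay compound 4 reaches only a limit, > 100000 nM. Chloro in place of benzyloxy on an aromatic carbon gives the first readable step at this position, an at least 2.3-fold higher number from compound 2 to compound 4 (0.36 log units; beyond the scatter), so among the compounds shown, this single change moves the number beyond the usual scatter and the benzyloxy compound remains the only one with a readable value. The steps linking compound 4 to compound 1 and compound 3 cannot be read because their ends all sit at one limit: the limit of > 100000 nM in this assay, at which 3 of the 4 values shown sit.

On these data alone, whether an amine or a longer chain in place of the benzyloxy group would keep a readable number, or lower it further, stays open. As far as these compounds go, the true values behind the limits also stay unknown, so the methoxyphenyl and chlorophenyl compounds cannot be ranked against one another.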